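Fluoro for methyl on an inactive oxadiazole analogue

A few compounds are considered here, and "the series" means these few. Any claim that something is new, unique, unknown or untested is made for them only; others in the source may bear on it.

Measured compounds:
- compound 1, `Cc1ccc(-c2cn(-c3ccc(CN4CCCC4)cc3)nn2)cc1Nc1nccc(-c2cccnc2)n1`, in a functional assay on K562 cells (Homo sapiens) for inhibition, read by MTT assay, with a stated time of 72 h (a higher number here means a weaker inhibitor, a lower number a stronger inhibitor), gives 3890 nM
- compound 2, `Cc1ccc(-n2cc(-c3ccc(CN4CCN(C)CC4)c(C(F)(F)F)c3)nn2)cc1Nc1nccc(-c2cccnc2)n1`, in this assay gives 40 nM
- compound 3, `Cc1ccc(-c2nnc(-c3ccc(C)c(C(F)(F)F)c3)o2)cc1Nc1nccc(-c2cccnc2)n1`, in this assay gives > 30000 nM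

For compound 3 the value is not a number but a limit of this assay, so only an upper bound on its strength is known. Among the three measured compounds it is the one that sits at the limit of > 30000 nM in this assay, at which 1 of the 3 values shown sits, the weakest end of what this set shows, while compound 1 and compound 2 both give real numbers. Compound 4, `Cc1ccc(-c2nnc(-c3ccc(F)c(C(F)(F)F)c3)o2)cc1Nc1nccc(-c2cccnc2)n1`, has not been measured yet. It differs from compound 3 in one place: fluoro in place of methyl on an aromatic carbon. The change is small, a single heavy atom swapped for another on an aromatic ring, and the rest of the molecule stays the same. Among the compounds with values here, no measured pair in this set mirrors this swap, so nothing here points to a direction; a step within the scatter, or none at all, is the most natural expectation. Compound 4 is therefore expected to remain at or near the limit in this assay, estimated at 40000 nM (range 10000 nM to 150000 nM), which corresponds to an expected step that the limit leaves unreadable from compound 3 to compound 4.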

Compound 4, half-maximal inhibitory concentration: 29700 nM
The estimate for compound 4 lay 1.3-fold (0.13 log units) above the measured number, within the range that was stated.
By their numbers in this assay, from the lowest: compound 2; then compound 1; then compound 4. At a limit, above all of these: compound 3.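

In this assay compound 4, which carries 4-fluoro-3-(trifluoromethyl)phenyl, gives 29700 nM, so fluoro at this carbon, ortho to a trifluoromethyl group, yields a real number. Compound 3, with methyl at this carbon, yields only a limit. The change of this single atom gives a number no higher from compound 3 to compound 4 (the limit leaves the size open), which shows a direction but no more than that. The size of this step cannot be read because compound 3 stands at a limit and has no number: the limit of > 30000 nM in this assay, at which 1 of the 4 values shown sits.

The compounds shown leave open whether another small group at this carbon, such as chloro, methoxy or an amine, would give a lower number on the oxadiazole analogue. They also leave open whether a carboxylic acid or a longer chain such as propyl would be accepted at this carbon.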